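A thiophen-2-yl swap in a series at its limit

The source may hold more compounds than are shown below. What is called first, only, known or untested is meant among the compounds shown, and "the series" means these compounds.

- Compound 1 `COc1cccc(-c2nc3cccc(-c4cc(OC)c(OC)c(OC)c4)c3o2)c1` gives > 25000 nM as a limit
- Compound 2 `COc1cc(-c2cccc3nc(-c4cccc(C)c4)oc23)cc(OC)c1OC` gives > 25000 nM as a limit

In a functional assay on NCI-H460 cells (Homo sapiens) for antiproliferative activity, read by MTT assay, with a stated time of 48 h (on this read-out lower numbers stand for stronger inhibition and higher numbers for weaker inhibition), compound 2 stands at > 25000 nM as a limit and not as a number. Compound 1 also ends in a limit, so the series has no numerical value yet. Among the measured compounds shown here, the one measured step that the two limits leave unreadable from compound 1 to compound 2 has no readable size. All the evidence so far is the limit of > 25000 nM in this assay, at which 2 of the 2 values shown sit, and it gives neither a size nor a direction for the next change.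

For the measured compounds named here, compound 3 `COc1cc(-c2cccc3nc(-c4cccs4)oc23)cc(OC)c1OC` carries thiophen-2-yl in place of 3-methylphenyl on an aromatic carbon of the shared core thiophen-2-yl in place of 3-methylphenyl on an aromatic carbon and no measured compound holds that group. Going by the values given here, with no measured step to draw on, no change beyond the usual scatter is expected in this assay and another limit is the likeliest result. The expected step of a number no higher from compound 2 to compound 3 (the limit leaves the size open) is only a rough estimate. For compound 3 the estimated value is 25000 nM with an expected range from 8000 nM to 50000 nM as the measurement is awaited.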

Compound 3, half-maximal inhibitory concentration: 1600 nM
The estimate for compound 3 lay 16-fold (1.19 log units) above the measured number, outside the stated range (below it).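

In this assay, the position on the five-membered aromatic ring with 1 nitrogen and 1 oxygen now proves able to move the read-out, something the earlier pair could not show, as the step between compound 1 and compound 2 cannot be read. Thiophen-2-yl in place of 3-methylphenyl gives an at least 15-fold lower number from compound 2 to compound 3 (1.19 log units; beyond the scatter), and the same group in place of 3-methoxyphenyl gives an at least 15-fold lower number from compound 1 to compound 3 (1.19 log units; beyond the scatter), so both readable steps run to a lower number, beyond the scatter. The only number in the series comes with thiophen-2-yl, while the two compounds with a substituted six-membered ring stay at the limit: the limit of > 25000 nM in this assay, at which 2 of the 3 values shown sit.

The compounds shown do not separate the part played by the five-membered ring, its sulfur atom or the lower count of heavy atoms, as thiophen-2-yl is the only such ring among them. As far as these compounds go, whether furan-2-yl, thiazol-2-yl, unsubstituted phenyl or a short alkyl chain at this place would also give a number stays open, as does the effect of a methyl group on the thiophen-2-yl ring.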